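Acetyl to methylsulfonyl on the aminopyridine nitrogen

This account rests on a few compounds, and the source may have more. Where it says the series, first, only, none or still open, it means among the compounds named here.

Measured compounds, with their numbers in a functional assay on K562 cells (Homo sapiens) for inhibition, read by MTT assay, with a stated time of 48 h; on this read-out higher numbers stand for weaker inhibition and lower numbers for stronger inhibition:
compound 1, `CC(C)(C)C(=O)Nc1ccc(-c2cccc(C(=O)N[C@H]3CN[C@@H](C(=O)Nc4ccc(Cl)c(C(F)(F)F)c4)C3)c2)cn1`: 28000 nM
compound 2, `CC(=O)Nc1ccc(-c2cccc(C(=O)N[C@H]3CN[C@@H](C(=O)Nc4ccc(Cl)c(C(F)(F)F)c4)C3)c2)cn1`: 8710 nM

Among the measured compounds shown here, compound 2 stands at the lower of the two numbers in this assay, and its only neighbour is compound 1. For the measured compounds named here, the single measured step, a 3.2-fold lower number from compound 1 to compound 2 (0.51 log units; beyond the scatter), came from methyl in place of tert-butyl on a carbonyl carbon, the carbonyl itself staying in place.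

Compound 3, `CS(=O)(=O)Nc1ccc(-c2cccc(C(=O)N[C@H]3CN[C@@H](C(=O)Nc4ccc(Cl)c(C(F)(F)F)c4)C3)c2)cn1`, differs from compound 2 by methylsulfonyl in place of acetyl on a nitrogen on an aromatic ring. Going by the values given here, the one step seen so far bears on the same attachment, but it altered only what sits on the carbonyl and left the amide intact, so it speaks at best indirectly to an exchange of the acyl group for a sulfonyl group. Among the compounds with values here, no pair shows what this exchange does. In this assay the step from compound 2 to compound 3 is therefore expected to stay within the scatter, with no clear direction, as a 1.1-fold lower number from compound 2 to compound 3 (0.04 log units; within the scatter).

Compound 3 is estimated at 8000 nM in this assay, within a range from 2500 nM to 25000 nM.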

Compound 3, half-maximal inhibitory concentration: 24600 nM
For compound 3 the middle estimate is 3.1-fold (0.49 log units) below the measured one; measured number inside the range.
By their numbers in this assay, from the lowest: compound 2; then compounds 3 and 1 (each within the scatter of the next).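

In this assay the exchange of acetyl for methylsulfonyl on the nitrogen on the aromatic ring gives a 2.8-fold higher number from compound 2 to compound 3 (0.45 log units; beyond the scatter) and so shows that this position responds to replacing the carbonyl itself, not only to changing what sits on the carbonyl. Set against the (tert-butyl)carbonyl group, methylsulfonyl gives a 1.1-fold lower number from compound 1 to compound 3 (0.06 log units; within the scatter) and leaves acetyl as the one group of the three on this nitrogen that stands apart, while two quite different replacements for it end up within the scatter of each other. Nothing available accounts for this result.

From the compounds shown here alone, it remains open whether the free amine, a formyl group or a urea on this nitrogen would match or pass acetyl, and whether a longer acyl chain such as propionyl would fall on the way from acetyl to the (tert-butyl)carbonyl group. Among the compounds shown here, it is equally open whether ethylsulfonyl or phenylsulfonyl would differ from methylsulfonyl, and whether the gap between acetyl and methylsulfonyl would hold on any core other than the one these three compounds share.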